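The source may report more compounds than this note shows. Statements on the series, on what has been measured and on what is new or still open speak of the compounds shown alone.

Measured in a functional assay on the whole organism for inhibition, with Mus musculus as the target; a higher number here means that more compound is needed for the effect, a lower number that less compound is needed:
Compound 1 `CCNC(=O)Nc1cccc2c1CN(C)CC2c1ccccc1`: 80 mg/kg
Compound 2 `CC(C)NCC(=O)Nc1cccc2c1CN(C)CC2c1ccccc1`: 14 mg/kg

Of these two, compound 2 has the lower number, at 14 mg/kg. Compound 3 `CCNCCC(=O)Nc1cccc2c1CN(C)CC2c1ccccc1` has the same atoms joined differently, with (ethylamino)methyl in place of isopropylamino on a saturated chain carbon bound to a carbonyl carbon. Among the compounds with values here, the only measured step is a 5.7-fold lower number from compound 1 to compound 2 (0.76 log units; beyond the scatter). Within the data shown here, it bears only indirectly, since it exchanged different groups, and no measured step tests this rearrangement. In this assay, no change beyond the scatter is therefore expected, and the estimated step is a 1.4-fold higher number from compound 2 to compound 3 (0.15 log units; within the scatter). For compound 3 the estimated value is 20 mg/kg, with an expected range of 7 mg/kg to 60 mg/kg.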

Compound 3, dose for half-maximal effect: > 200 mg/kg
Compound 3 ended at the assay's limit (the forecaster's own chance of this, stated with the estimate: 5%); at least 10-fold (1.00 log units) between middle value and limit.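

Rearranging the same atoms from (isopropylamino)methyl to 2-(ethylamino)ethyl on the carbonyl carbon gives an at least 14-fold higher number from compound 2 to compound 3 (1.15 log units; beyond the scatter), so this position responds to how the side chain is joined and not only to what it contains. The gain seen earlier therefore does not carry over to every amine-bearing chain, as the comparison with the ethylamino group shows: an at least 2.5-fold higher number from compound 1 to compound 3 (0.39 log units; beyond the scatter). The value of compound 3 is a limit and not a number: the limit of > 200 mg/kg in this assay, at which 1 of the 3 values shown sits.

The compounds shown leave open whether chain length or the ethyl group on the nitrogen accounts for this loss, since both differ at once. From the compounds shown here alone, how a 2-(isopropylamino)ethyl or a dimethylamino group would fare at this position also remains open.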